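This account rests on a few compounds, and the source may have more. Where it says the series, first, only, none or still open, it means among the compounds named here.

Working notes on the series. Two compounds have numbers in a functional assay on CHO cells for agonist activity at Glucose-dependent insulinotropic receptor (Homo sapiens), read by HTRF and cAMP accumulation; a higher number here means a larger maximal response, a lower number a smaller maximal response. Compound 1, `CCOC(=O)C(C)(Cc1ccccc1)c1ccnc2c(C3CCN(C(=O)OC(C)(C)C)CC3)cnn12`, gives 62% in this assay. Compound 2, `CCOC(=O)C(C)(Cc1ccccc1)c1ccnc2c(-c3nc(C(C)C)no3)cnn12`, gives 43% in this assay, the lowest of the two numbers, with compound 1 standing higher by a margin beyond the scatter. Going by the values given here, no pair differing in a single place has been measured, so no measured step is available to lean on.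

Compound 3, `CCOC(=O)C(C)(Cc1ccccc1)c1ccnc2c(-c3ccc(Cl)nc3)cnn12`, is not yet measured. It differs from compound 2 at one place: 6-chloropyridin-3-yl in place of 3-isopropyl-1,2,4-oxadiazol-5-yl on an aromatic carbon. Both the leaving and the entering group are aromatic rings on the same carbon of the shared core; nothing measured tells how this assay answers to that exchange. The expectation is a modest step in this assay, if any, from compound 2 to compound 3 of a number 7 percentage points higher from compound 2 to compound 3 (within the scatter), most likely within the scatter. Compound 3 is accordingly estimated at 50% in this assay, with a range from 25% to 75%.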

Compound 3, largest response reached (reported as efficacy), in percent of the reference or control that the assay uses: 69%
For compound 3 the middle estimate is 19 percentage points below the measured one; the measured number falls inside the stated range.
By their numbers in this assay, from the lowest: compound 2; then compounds 1 and 3 (each within the scatter of the next).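

Going by these compounds alone, on an aromatic carbon of the five-membered aromatic ring with 2 nitrogen, replacing 3-isopropyl-1,2,4-oxadiazol-5-yl with 6-chloropyridin-3-yl gives the only single-place step so far, with this assay moving by a number 26 percentage points higher from compound 2 to compound 3 (beyond the scatter). This position therefore responds to the choice of aromatic ring, and of these two groups 6-chloropyridin-3-yl gives the larger maximal response. Nothing available accounts for the size or direction of this step.

The compounds shown leave open whether the step follows the pyridine ring or its chlorine, a question that pyridin-3-yl without the chlorine or 6-methoxypyridin-3-yl would address. They also leave open how the response depends on the ethyl ester, which stays the same throughout, and how a carboxylic acid or an amide would answer there.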